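The compounds below may be only part of what the source reports. "The series", "measured", "known", "first", "only" and "open" are said of these compounds alone.

Measured in an ADME assay on T29 cells (Homo sapiens) for cytotoxicity, read by sulforhodamine B assay, with a stated time of 3 days; on this read-out higher numbers stand for weaker inhibition and lower numbers for stronger inhibition:
- compound 1 `OCc1cn(Cc2ccc(Cl)cc2)c2ccccc12`: > 31600 nM
- compound 2 `Cc1ccc(Cn2cc(CO)c3ccccc32)cc1`: > 31600 nM
- compound 3 `COc1ccc2c(c1)c(CO)cn2Cc1ccc(Cl)cc1`: > 31600 nM

Compound 1 gives only a limit in this assay, > 31600 nM, and not a number. Compound 2 likewise gives only a limit. Compound 3 does the same. Among the measured compounds shown here, the series so far therefore offers (the limit of > 31600 nM in this assay, at which 3 of the 3 values shown sit).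

Compound 4 `CC(=O)OCc1cn(Cc2ccc(Cl)cc2)c2ccccc12` differs from compound 1 by acetyl in place of hydrogen on an oxygen on a saturated carbon. This is acetyl in place of hydrogen on an oxygen on a saturated carbon, or hydroxymethyl to acetoxymethyl.

For the measured compounds named here, two measured steps bear on this change only indirectly, since neither alters the hydroxymethyl group. Methyl in place of chloro is a step that the two limits leave unreadable from compound 1 to compound 2, and methoxy in place of hydrogen is a step that the two limits leave unreadable from compound 1 to compound 3. Neither has a size that can guide the estimate. Given (the limit of > 31600 nM in this assay, at which 3 of the 3 values shown sit), no step beyond the scatter is expected in this assay, in either direction, although this change itself is untested.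

The expected step is a number no higher from compound 1 to compound 4 (the limit leaves the size open). For compound 4 the estimated value is 31600 nM, with an expected range of 10000 nM to 60000 nM.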

Compound 4, half-maximal inhibitory concentration: > 31600 nM
Compound 4 ended at the assay's limit (the forecaster's own chance of this, stated with the estimate: 75%); the middle value lies on the limit itself.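

Compound 4, like compound 1, gives only a limit in this assay, so no size can be read for the change from hydroxymethyl to acetoxymethyl: the limit of > 31600 nM in this assay, at which 4 of the 4 values shown sit.

The compounds shown leave open what actual number any of them would reach in this assay, and whether any of these changes moves it.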